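The source may hold more compounds than are shown below. What is called first, only, known or untested is meant among the compounds shown, and "the series" means these compounds.

Measured so far:
- compound 1 `COc1ccc(-c2cn(Cc3ccccc3)nn2)cc1`: 146000 nM
- compound 2 `Cc1ccc(-c2cn(Cc3ccccc3)nn2)cc1`: 84400 nM

Both numbers come from a functional assay on HT-1080 cells (Homo sapiens) for antiproliferative activity, read by MTT assay, with a stated time of 72 h; a higher number here means a weaker inhibitor, a lower number a stronger inhibitor. Compound 2 and compound 1 lie within the scatter of each other, since the change of a 1.7-fold lower number from compound 1 to compound 2 (0.24 log units; within the scatter) is too small to count. Compound 3 `FC(F)(F)c1ccc(-c2cn(Cc3ccccc3)nn2)cc1` is not yet measured; it differs from compound 2 by trifluoromethyl in place of methyl on an aromatic carbon. For the measured compounds named here, the only measured step that bears on it, the step from compound 1 to compound 2, was within the scatter. A change at the same place is therefore expected to give no step beyond the scatter in this assay, so compound 3 is estimated at 70000 nM, between 25000 nM and 200000 nM, which means an expected step of a 1.2-fold lower number from compound 2 to compound 3 (0.08 log units; within the scatter).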

Compound 3, half-maximal inhibitory concentration: 57700 nM
Compound 3: the middle estimate sits 1.2-fold (0.08 log units) above what was measured, within the range that was stated.
By their numbers in this assay, from the lowest: compounds 3, 2 and 1 (each within the scatter of the next, the first and the last beyond it).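

In this assay trifluoromethyl in place of methyl gives no difference that can be read (a 1.5-fold lower number from compound 2 to compound 3 (0.17 log units; within the scatter)) at this position on the aromatic ring. Across the three groups, the comparison of trifluoromethyl with methoxy is the first to pass the scatter (a 2.5-fold lower number from compound 1 to compound 3 (0.40 log units; beyond the scatter)), although the step is modest and compound 2 lies within the scatter of both other compounds. Nothing measured here explains this step. The compounds shown leave open whether an amine, a carboxylic acid or a longer chain at this position would give a larger step.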